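A few compounds are considered here, and "the series" means these few. Any claim that something is new, unique, unknown or untested is made for them only; others in the source may bear on it.

Of the compounds shown here, three have so far been tested in an ADME assay on L6 cells (Rattus norvegicus) for cytotoxicity, read by resazurin assay, with a stated time of 72 h; a lower number here means a stronger inhibitor, a higher number a weaker inhibitor. Compound 1 `O=[N+]([O-])c1ncn(CCCNc2nc3ccccc3s2)n1` gives 163000 nM. Compound 3 `O=[N+]([O-])c1ncn(CCCNc2nc3ccc(Cl)cc3s2)n1` gives 102000 nM. Compound 2 `O=[N+]([O-])c1nccn1CCCNc1nc2ccc(Cl)cc2s1` gives 49500 nM, the lowest of the three numbers; the difference between the core of compound 2 and the core of compound 3 is not broken down here.

Compound 3 and compound 1 differ in a single place, (hydrogen in place of chloro on an aromatic carbon), and this change gave a 1.6-fold higher number from compound 3 to compound 1 (0.20 log units; within the scatter).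

Compound 4 `O=[N+]([O-])c1nccn1CCCNc1nc2ccccc2s1` has not yet been measured. For the measured compounds named here, it differs from compound 2 in one place, (hydrogen in place of chloro on an aromatic carbon), which is the same change as the one between compound 3 and compound 1, now made on the core of compound 2. Because a 1.6-fold higher number from compound 3 to compound 1 (0.20 log units; within the scatter) was a small step, a step of similar size is expected from compound 2 to compound 4, namely a 1.6-fold higher number from compound 2 to compound 4 (0.21 log units; within the scatter). Compound 4 is therefore estimated at 80000 nM in this assay, with a likely range from 35000 nM to 180000 nM before the measurement itself is known.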

Compound 4, half-maximal inhibitory concentration: 176000 nM
Beside the measured number, compound 4's estimate is 2.2-fold (0.34 log units) below it, within the range that was stated.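

In this assay, putting hydrogen in place of chloro on the core of compound 2 gave a 3.6-fold higher number from compound 2 to compound 4 (0.55 log units; beyond the scatter), a step larger than the usual scatter, while the same change on the other core stayed within it. Set side by side, the two steps point the same way, and the gap between them is no larger than the scatter of two such steps: the same change on two cores in this assay, a 1.6-fold higher number (0.20 log units; within the scatter) from compound 3 to compound 1 and a 3.6-fold higher number (0.55 log units; beyond the scatter) from compound 2 to compound 4, 2.2-fold (0.35 log units) apart, within the scatter of two such steps. On these two cores, then, the change carries over in direction, and the data show no real difference in its size, but two pairs of compounds cannot prove that the size is the same or say how the change would behave on any other core.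

On these data alone, what a fluoro or methoxy group would do in the place of the chloro stays open, and so does the effect of a longer chain between the two ring parts. As far as these compounds go, whether a third core would show a step of similar size also remains unknown.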